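The source may report more compounds than this note shows. Statements on the series, on what has been measured and on what is new or still open speak of the compounds shown alone.

Measured so far:
- compound 1, `O=[N+]([O-])c1ccc(O)c(CSc2ncnc3c2ncn3[C@@H]2O[C@H](CO)[C@@H](O)[C@H]2O)c1`: 33.1 nM
- compound 2, `CCCCSc1nc(N)nc2c1ncn2[C@@H]1O[C@H](CO)[C@@H](O)[C@H]1O`: 12000 nM
- compound 3, `Cc1c(CNc2ncnc3c2ncn3[C@@H]2O[C@H](CO)[C@@H](O)[C@H]2O)cccc1[N+](=O)[O-]`: 427 nM

In an assay on isolated protein for binding affinity to Equilibrative nucleoside transporter 1 (Homo sapiens) (a lower number here means a stronger inhibitor, a higher number a weaker inhibitor), compound 3 stands second highest of the three numbers. Its nearest neighbour is compound 1, whose number is markedly lower, and the gap to it lies beyond the scatter; compound 2 gives a far higher number, again beyond the scatter. Compound 3 thus sits between the two, closer in log terms to compound 1 than to compound 2, with the remaining structures giving no single-point comparison to it.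

Compound 4, `Cc1ccc([N+](=O)[O-])c(CNc2ncnc3c2ncn3[C@@H]2O[C@H](CO)[C@@H](O)[C@H]2O)c1`, is an isomer of compound 3 with the same atoms joined differently: 5-methyl-2-nitrophenyl in place of 2-methyl-3-nitrophenyl on a saturated chain carbon bound to a nitrogen on an aromatic ring. Among the measured compounds shown here, no pair of measured compounds shows the effect of rearranging the substituents on that ring, so the direction of the step cannot be read from the data. The expectation is a step in this assay of no clear size beyond the scatter, with a wide range to either side, since only the aryl substitution pattern moves while the shared core and the linker stay. Compound 4 is therefore estimated at 500 nM, range 120 nM to 2000 nM, which corresponds to an expected step of a 1.2-fold higher number from compound 3 to compound 4 (0.07 log units; within the scatter).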

Compound 4, half-maximal inhibitory concentration: 1290 nM
For compound 4 the middle estimate is 2.6-fold (0.41 log units) below the measured one; the range from low to high includes it.
By their numbers in this assay, from the lowest: compound 1; then compound 3; then compound 4; then compound 2.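

With the shared core and the linker held, 5-methyl-2-nitrophenyl in place of 2-methyl-3-nitrophenyl on a saturated chain carbon bound to a nitrogen on an aromatic ring gives a 3.0-fold higher number from compound 3 to compound 4 (0.48 log units; beyond the scatter) in this assay. Among the compounds shown here, this is the first pair that differs in one place, and it shows that rearranging the methyl and nitro groups on this ring is enough to move the number beyond the scatter, although the atoms and the counts of hydrogen-bond donors and acceptors in the group stay the same. Nothing measured here accounts for the step.

Which of the two substituents carries the step remains open, as does the reading in this assay for an amine or a carboxylic acid in place of the nitro group. Also open, on these data alone, is whether the same rearrangement would give a similar step with a thioether linker.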